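The source may report more compounds than this note shows. Statements on the series, on what has been measured and on what is new or still open speak of the compounds shown alone.

Of the compounds shown here, three sharing one core have been tested in an assay on membranes from HeLa cells for displacement of a labelled ligand from adenosine receptor A3 (Homo sapiens), read by scintillation counting, with a stated time of 180 min, tested at 1 uM; on this read-out higher numbers stand for more inhibition at the one concentration tested (going by the name of the read-out) and lower numbers for less inhibition. Compound 1 `CCCOC(=O)C1=C(C)NC(=O)NC1c1cccs1` gives 32%. Compound 2 `CCCOC(=O)C1=C(C)NC(=S)NC1c1cccs1` gives 10%. Compound 3 `COC(=O)C1=C(C)N(C)C(=O)NC1c1ccco1` gives 9%. Among these three numbers compound 3 holds the lowest, but its nearest neighbour, compound 2, lies within the usual scatter of it, so the two cannot be placed in an order; compound 1 alone stands above compound 3 by a margin beyond the scatter. Going by the values given here, none of the measured pairs differs in a single place, so no step for one change at a time is available. Compound 4 `CC1=C(C(=O)OCC(C)C)C(c2ccco2)NC(=O)N1C` has not yet been measured. It differs from compound 3 in one place: isopropyl in place of hydrogen on a saturated chain carbon bound to an oxygen next to a carbonyl group. Compound 1 carries a longer ester chain and the higher value 32%, yet it differs from compound 3 in other places as well, so that number cannot be read as the effect of the chain alone. With no single-change comparison to lean on, the step from compound 3 to compound 4 in this assay is expected to be small, a number 6 percentage points higher from compound 3 to compound 4 (within the scatter), and not clearly beyond the scatter. Compound 4 is therefore estimated at 15%, with a range from 0% to 35%.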

Compound 4, a percentage reported as inhibition, at one concentration (the size of the read-out at that concentration, not a potency): 23%
The estimate for compound 4 lay 8 percentage points below the measured number; the measured number falls inside the stated range.
By their numbers in this assay, from the lowest: compounds 3 and 2 (each within the scatter of the next); then compounds 4 and 1 (each within the scatter of the next).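

In this assay, going by these compounds alone, the exchange of methoxycarbonyl for isobutoxycarbonyl gives a number 14 percentage points higher from compound 3 to compound 4 (beyond the scatter) and is the first comparison here in which a single change stands alone, so the ester chain can now be said to move the number by itself, whereas the higher value of compound 1 could not be separated from its other differences. The step is modest and comes from one concentration, so it shows that this place, a saturated chain carbon bound to an oxygen next to a carbonyl group, accepts isopropyl with a gain in inhibition, but it does not show how far potency changes. Nothing at hand bears on why the isobutoxycarbonyl compound gives the higher number.

From the compounds shown here alone, whether the gain follows the size of the chain or its branching stays open: an unbranched butyl chain or a longer hexyl chain at this place would separate the two, and a carboxylic acid in place of the ester would test whether any chain is needed. Going by these compounds, it also remains open whether the same exchange would give a similar step on the core of compound 1.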